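This account rests on a few compounds, and the source may have more. Where it says the series, first, only, none or still open, it means among the compounds named here.

The measured compounds so far:
compound 1, `Clc1ccc2[nH]c(SCc3ccccc3CCCc3ccccc3)nc2c1`, giving 19%;
compound 2, `c1ccc(CCc2ccccc2CSC2=NCCS2)cc1`, giving 0%;
compound 3, `c1ccc(CSc2nc3ccccc3[nH]2)cc1`, giving -42%.

All three numbers come from an assay on isolated protein for inhibition of Indoleamine 2,3-dioxygenase 1 (Homo sapiens), with a stated time of 60 min, tested at 10 uM (on this read-out lower numbers stand for less inhibition and higher numbers for more inhibition at the one concentration tested (going by the name of the read-out)), a read-out taken at a single concentration, so each tells how much of the enzyme's activity was blocked at that one dose, that is, how strong or weak the effect was at that concentration and nothing more. Compound 1 stands highest of the three. Compound 2 sits below it by a gap beyond the usual scatter, and compound 3 sits lower still, also beyond the scatter; compound 3 is the only one of the three whose number falls below zero.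

Compound 4, `Clc1ccc2[nH]c(SCc3ccccc3Cc3ccccc3)nc2c1`, has not yet been tested in this assay. It differs from compound 1 in one place: phenyl in place of phenethyl on a saturated chain carbon bound to an aromatic carbon. Read one bond further out, the same change turns a 3-phenylpropyl into a benzyl, so the second aromatic ring is drawn closer to the shared core while everything else stays as in compound 1.

Among the measured compounds shown here, no measured pair shows exactly this shortening, so the expectation rests on compound 1 alone. In this assay the step from compound 1 to compound 4 is expected to be small and downward, staying within the scatter: a number 9 percentage points lower from compound 1 to compound 4 (within the scatter). Compound 4 is therefore estimated at 10%, with a range from -25% to 40%.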

Compound 4, a percentage reported as inhibition, at one concentration (the size of the read-out at that concentration, not a potency): 46%
Compound 4: middle estimate off by 36 percentage points, on the low side, outside the stated range (above it).
By their numbers in this assay, from the lowest: compound 3; then compound 2; then compound 1; then compound 4.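

In this assay, the change from phenethyl to phenyl on a saturated chain carbon bound to an aromatic carbon, which reads as 3-phenylpropyl to benzyl when cut one bond further out, gives a clear step: a number 27 percentage points higher from compound 1 to compound 4 (beyond the scatter). Among the compounds shown here, this is the first comparison in the set between two compounds that differ in one place, and it shows that the number at this position responds to how the second aromatic ring is attached to the shared core, with benzyl ahead of 3-phenylpropyl in this pair. The second ring stays in both compounds, and the group that enters has 6 heavy atoms where the group that leaves has 8, all carbon, with no hydrogen-bond donors or acceptors on either side.

No measurement shown here accounts for the rise in the number, so this pair describes the change without explaining it. A single pair also leaves open whether the second aromatic ring is needed at all, and how the number would respond if an amine or a carboxylic acid stood in its place on the same core.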